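Piperidine to methylpiperazine at the propoxy chain end

The source may hold more compounds than are shown below. What is called first, only, known or untested is meant among the compounds shown, and "the series" means these compounds.

Compound 1 `COc1cc2c(Oc3ccc(NC(=O)c4nn(-c5ccccc5C)c(=O)cc4C)cc3F)ccnc2cc1OCCCN1CCN(C)CC1` gives 3720 nM in a functional assay on U-87MG ATCC cells (Homo sapiens) for inhibition, read by MTT assay, with a stated time of 72 h; a lower number here means a stronger inhibitor, a higher number a weaker inhibitor. Compound 2 `COc1cc2c(Oc3ccc(NC(=O)c4nn(-c5ccccc5C(F)(F)F)c(=O)cc4C)cc3F)ccnc2cc1OCCCN1CCCCC1` gives 1150 nM in this assay and stands lowest of the two numbers, with compound 1 beyond the scatter above it; the two differ in more than one place, so no single change is credited. Compound 3 `COc1cc2c(Oc3ccc(NC(=O)c4nn(-c5ccccc5C(F)(F)F)c(=O)cc4C)cc3F)ccnc2cc1OCCCN1CCN(C)CC1` differs from compound 2 by 4-methylpiperazin-1-yl in place of piperidin-1-yl on a saturated chain carbon, three bonds along the chain from an oxygen on an aromatic ring. Among the measured compounds shown here, no step between measured compounds isolates this change, so a step of a 1.3-fold higher number from compound 2 to compound 3 (0.12 log units; within the scatter) in this assay is expected, none beyond the scatter. Compound 3 is estimated at 1500 nM, within 600 nM to 4000 nM.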

Compound 3, half-maximal inhibitory concentration: 1170 nM
Beside the measured number, compound 3's estimate is 1.3-fold (0.11 log units) above it; measured number inside the range.
By their numbers in this assay, from the lowest: compounds 2 and 3 (each within the scatter of the next); then compound 1.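

In this assay, 4-methylpiperazin-1-yl in place of piperidin-1-yl on the saturated chain carbon leaves the two numbers within the scatter of each other (a 1.0-fold higher number from compound 2 to compound 3 (0.01 log units; within the scatter)), so this exchange shows no readable effect with trifluoromethyl held fixed. Compound 3 also isolates the aromatic substituent: trifluoromethyl in place of methyl on the aromatic carbon accounts for a step beyond the scatter (a 3.2-fold lower number from compound 1 to compound 3 (0.50 log units; beyond the scatter)). No measurement offered here explains either step.

Open, from the compounds shown here alone, is whether morpholine or dimethylamino on the same chain, or a longer chain, would read alike. Also open, going by these compounds, is whether the piperidine and methylpiperazine match holds with methyl on the aromatic carbon.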